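The source may hold more compounds than are shown below. What is called first, only, known or untested is meant among the compounds shown, and "the series" means these compounds.

Working notes on the series. Of the compounds shown here, three have been measured in an assay on HL-60 cells for inhibition of glutathione S-transferase P (Homo sapiens); on this read-out higher numbers stand for weaker inhibition and lower numbers for stronger inhibition. Compound 1 `C=C(C)C(=O)c1ccc(OCc2nc(-c3ccc(C(F)(F)F)cc3)no2)cc1Br` gives 1300 nM in this assay. Compound 2 `C=C(C)C(=O)c1ccc(OCc2nc(C)no2)cc1Cl` gives 2100 nM in this assay. Compound 3 `C=C(CC)C(=O)c1ccc(OCc2nc(C)no2)c(Cl)c1Cl` gives 4000 nM in this assay, the highest of the three numbers; its gap to compound 2 lies within the scatter, its gap to compound 1 lies beyond it. Compounds 1 and 2 differ at more than one place, so their values cannot be read as one step; what they show is that compound 1, which carries an aryl group on the five-membered ring where compound 2 carries methyl, has the lower number.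

Compound 4 `C=C(CC)C(=O)c1ccc(OCc2nc(-c3ccc(OC)cc3)no2)c(Cl)c1Cl` has not yet been measured in this assay. Against compound 3 the change is 4-methoxyphenyl in place of methyl on an aromatic carbon. For the measured compounds named here, no measured pair isolates this change. Going by the values given here, the only hint comes from compound 1 against compound 2, where the aryl-bearing compound has the lower value, but that pair also differs elsewhere, so the hint is weak. The expectation is a step from compound 3 to compound 4 of a 1.6-fold lower number from compound 3 to compound 4 (0.20 log units; within the scatter), toward a lower number and of a size that may not exceed the scatter. Compound 4 is thus estimated at 2500 nM in this assay, within a range of 1000 nM to 6500 nM.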

Compound 4, half-maximal inhibitory concentration: 3800 nM
The estimate for compound 4 lay 1.5-fold (0.18 log units) below the measured number; the range from low to high includes it.
By their numbers in this assay, from the lowest: compounds 1, 2, 4 and 3 (each within the scatter of the next, the first and the last beyond it).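

For the compounds shown here, with the rest of the structure held fixed, the change to 4-methoxyphenyl in place of methyl on the five-membered aromatic ring gives a 1.1-fold lower number from compound 3 to compound 4 (0.02 log units; within the scatter) in this assay, and this is the first pair that isolates this position. The aromatic carbon between two ring nitrogen atoms can therefore carry a group of 8 heavy atoms, with a six-membered aromatic ring and 1 hydrogen-bond acceptor, in place of a single carbon without a step that can be told from the scatter, so on the core of compound 3 this read-out does not separate the two groups. No measurement at hand bears on why methyl and 4-methoxyphenyl read alike here.

Open, on these data alone, is whether a different kind of group at this position, such as an amine, a carboxylic acid or a longer alkyl chain, would give a step beyond the scatter. Also open, as far as these compounds go, is whether the same exchange of methyl for 4-methoxyphenyl on the core of compound 2 would give a step of similar size.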